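Oxime series: chloro for methoxy on the oxime-bearing ring

The compounds below may be only part of what the source reports. "The series", "measured", "known", "first", "only" and "open" are said of these compounds alone.

Measured so far in a functional assay (Mus musculus, strain Balb/c) for inhibition, read by ELISA, with a stated time of 72 h; a lower number here means a stronger inhibitor, a higher number a weaker inhibitor:
compound 1 `COc1ccc(C(/C=C/c2ccc(Br)cc2)=N/O)cc1` gives 13900 nM
compound 2 `COc1ccc(/C=C/C(=N\O)c2ccc(OC)cc2)cc1` gives 12300 nM

Going by the values given here, compound 2 stands alongside compound 1; the only step in this assay, a 1.1-fold lower number from compound 1 to compound 2 (0.05 log units; within the scatter), separates nothing. Compound 3 `COc1ccc(/C=C/C(=N\O)c2ccc(Cl)cc2)cc1` differs from compound 2 by chloro in place of methoxy on an aromatic carbon. Among the compounds with values here, the one bearing step swaps a halogen and a methoxy on the other ring and stayed within the scatter, so no step beyond the scatter is expected here, in either direction. Compound 3 is therefore expected to give 13000 nM in this assay, with a range of 6000 nM to 28000 nM, an estimated step of a 1.1-fold higher number from compound 2 to compound 3 (0.02 log units; within the scatter).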

Compound 3, half-maximal inhibitory concentration: 5850 nM
The estimate for compound 3 lay 2.2-fold (0.35 log units) above the measured number; the measured number lies below the stated range.
By their numbers in this assay, from the lowest: compound 3; then compounds 2 and 1 (each within the scatter of the next).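

Going by these compounds alone, on the oxime-bearing ring, the aromatic carbon para to a large group is sensitive to substitution in this assay: chloro in place of methoxy gives the only step beyond the scatter so far (a 2.1-fold lower number from compound 2 to compound 3 (0.32 log units; beyond the scatter)), though a modest one resting on a single pair. The change of bromo to methoxy on the other ring stayed within the scatter (a 1.1-fold lower number from compound 1 to compound 2 (0.05 log units; within the scatter)). Nothing available explains the difference between these two changes.

As far as these compounds go, it remains open whether the step comes from adding chloro or from removing methoxy. Bare hydrogen, fluoro, an amine or a carboxylic acid at this position would help separate the two.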